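Opening the cyclopentyl group on the shared core

This account rests on a few compounds, and the source may have more. Where it says the series, first, only, none or still open, it means among the compounds named here.

Measured in a functional assay on MDA-MB-231 cells (Homo sapiens) for antiproliferative activity, read by sulforhodamine B assay; on this read-out higher numbers stand for weaker inhibition of growth and lower numbers for stronger inhibition of growth:
- compound 1 `CC(C)=CCOc1cccc(O)c1C(=O)/C=C/c1ccc(O)cc1`: > 30000 nM
- compound 2 `O=C(/C=C/c1ccc(O)cc1)c1c(O)cccc1OCC1CCCC1`: 3410 nM

The value of compound 1 is a limit. Among the compounds with values here, compound 2 gives 3410 nM, the only actual number so far. Compound 3 `CCC(CC)COc1cccc(O)c1C(=O)/C=C/c1ccc(O)cc1` carries pentan-3-yl in place of cyclopentyl on a saturated chain carbon bound to an oxygen on an aromatic ring. Within the data shown here, one measured step bears on this place, an at least 8.7-fold lower number from compound 1 to compound 2 (0.94 log units; beyond the scatter), so this assay responds to a change there. Compound 3 keeps the count of heavy atoms, so only a small shift toward weaker inhibition is expected, with the expected step being a 1.5-fold higher number from compound 2 to compound 3 (0.17 log units; within the scatter). For compound 3 the estimate is 5000 nM, with an expected range of 1800 nM to 15000 nM.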

Compound 3, concentration for 50% growth inhibition: 3130 nM
For compound 3 the middle estimate is 1.6-fold (0.20 log units) above the measured one; the measured number falls inside the stated range.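

In this assay, the ring is not required at this position: pentan-3-yl in place of cyclopentyl gives a 1.1-fold lower number from compound 2 to compound 3 (0.04 log units; within the scatter). With pentan-3-yl in place of 2-methylprop-1-en-1-yl, the result is an at least 9.5-fold lower number from compound 1 to compound 3 (0.98 log units; beyond the scatter), so the stronger inhibition seen with cyclopentyl also appears with an open group. Compound 1 stands at a limit, so this step gives only a bound on the size of the change: the limit of > 30000 nM in this assay, at which 1 of the 3 values shown sits.

Open, going by these compounds, is whether a straight hexyl chain, or a group carrying an amine at this place, would keep inhibition at the level of compound 2 and compound 3.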